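A few compounds are considered here, and "the series" means these few. Any claim that something is new, unique, unknown or untested is made for them only; others in the source may bear on it.

For the measured compounds named here, compound 1 `CC(CC(=O)O)N1Cc2ccc(NC(=O)CC3CCNCC3)cc2C1=O` gives 2700 nM in a functional assay on a cell-free system (Platelet, plasma, Homo sapiens) for inhibition (on this read-out higher numbers stand for weaker inhibition and lower numbers for stronger inhibition), the lowest of the three numbers so far. Compound 2 `CC(CC(=O)O)N1Cc2ccc(NC(=O)CCCC3CCNCC3)cc2C1=O` gives 5400 nM, a step of a 2.0-fold higher number from compound 1 to compound 2 (0.30 log units; within the scatter). Compound 3 `O=C(O)CN1Cc2ccc(NC(=O)c3ccc(C4CCNCC4)cc3)cc2C1=O` gives 24000 nM, beyond the scatter from compound 1, but it differs from compound 1 in more than one place and so gives no reading on any single change. Compound 4 `O=C(O)CCCN1Cc2ccc(NC(=O)CC3CCNCC3)cc2C1=O` differs from compound 1 only by 3-carboxypropyl in place of 1-(carboxymethyl)ethyl on an amide-type nitrogen in a ring. Going by the values given here, no measured step touches this part of the core: the only one-place step, a 2.0-fold higher number from compound 1 to compound 2 (0.30 log units; within the scatter), sits on the amide side and stays within the scatter. With nothing pointing either way, compound 4 is expected at 3000 nM, with a range of 1200 nM to 8000 nM, a step of a 1.1-fold higher number from compound 1 to compound 4 (0.05 log units; within the scatter) not beyond the scatter.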

Compound 4, half-maximal inhibitory concentration: 1800 nM
Compound 4: middle estimate off by 1.7-fold (0.22 log units), on the high side, within the range that was stated.
By their numbers in this assay, from the lowest: compounds 4, 1 and 2 (each within the scatter of the next, the first and the last beyond it); then compound 3.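

For the compounds shown here, on the amide-type nitrogen in a ring, 3-carboxypropyl in place of 1-(carboxymethyl)ethyl gives a 1.5-fold lower number from compound 1 to compound 4 (0.18 log units; within the scatter) in this assay, the first one-place reading at this position. With the same atoms joined differently, this side chain shows no change beyond the scatter in this single pair. Nothing at hand explains this result.

Open, from the compounds shown here alone, is whether 4-carboxybutyl, or a methyl ester in place of the carboxylic acid, would move the number beyond the scatter. Also open, going by these compounds, is whether the same change reads alike on the amide side of compound 2.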